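The source may hold more compounds than are shown below. What is called first, only, known or untested is meant among the compounds shown, and "the series" means these compounds.

In a functional assay on MDA-MB-231 cells (Homo sapiens) for antiproliferative activity, read by MTT assay, with a stated time of 72 h (a lower number here means a stronger inhibitor, a higher number a weaker inhibitor), compound 2 `O=C(Nc1cccc(C(=O)O/N=C2\CCCc3onc(-c4cccc(F)c4)c32)c1)c1cccc(F)c1` gives 8700 nM, the only figure among the three values shown that is an actual number. Compound 1 `O/N=C1\CCCc2onc(-c3cccc(F)c3)c21` gives > 25000 nM, which is a limit of the assay rather than a number. Compound 3 `COc1ccc(-c2onc3c2/C(=N/OC(=O)c2cccc(NC(=O)c4cccc(F)c4)c2)CC(C)(C)C3)cc1OC` likewise gives > 25000 nM, again a limit. Among the compounds with values here, two of the three values thus sit at the limit of > 25000 nM in this assay, at which 2 of the 3 values shown sit, and compound 2 stands alone as the single measured number. Compound 4 `COc1ccc(-c2noc3c2/C(=N/OC(=O)c2cccc(NC(=O)c4cccc(F)c4)c2)CCC3)cc1OC` has not yet been measured; it differs from compound 2 by 3,4-dimethoxyphenyl in place of 3-fluorophenyl on an aromatic carbon. Within the data shown here, no step between two measured compounds that differ in one place is known, so the size of this change cannot be read off directly. Compound 3, which also carries 3,4-dimethoxyphenyl, reaches only the limit of > 25000 nM. The change is therefore expected to weaken activity, by an estimated 2.3-fold higher number from compound 2 to compound 4 (0.36 log units; beyond the scatter), with a fair chance that only a limit results. Compound 4 is estimated at 20000 nM, within a range from 7000 nM to 60000 nM.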

Compound 4, half-maximal inhibitory concentration: > 25000 nM
Compound 4: a limit, no number (the forecaster's own chance of this, stated with the estimate: 55%); middle value at least 1.2-fold (0.09 log units) away from the limit.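

Within the data shown here, on an aromatic carbon of the five-membered aromatic ring with 1 nitrogen and 1 oxygen, next to the ring nitrogen, 3,4-dimethoxyphenyl in place of 3-fluorophenyl gives the first step between two measured compounds that differ in one place, an at least 2.8-fold higher number from compound 2 to compound 4 (0.45 log units; beyond the scatter), in this assay. Compound 4 gives > 25000 nM, which is a limit and not a number. The step therefore fixes only a smallest size for the change, and compound 2 remains the only compound shown with an actual number: the limit of > 25000 nM in this assay, at which 3 of the 4 values shown sit.

The compounds shown leave open whether the step follows from the departure of the fluorine or from the arrival of the two methoxy groups, as the two change together. Going by these compounds, how a plain phenyl, or a phenyl with a single methoxy group, would read at this position also stays open.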